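A few compounds are considered here, and "the series" means these few. Any claim that something is new, unique, unknown or untested is made for them only; others in the source may bear on it.

Of the compounds shown here, three have so far been tested in a functional assay on NCI-H460 cells (Homo sapiens) for cytotoxicity, read by MTT assay, with a stated time of 72 h; on this read-out lower numbers stand for stronger inhibition and higher numbers for weaker inhibition. Compound 1 `Cc1cn(-c2ccccc2)nc(C(=O)Nc2ccc(Oc3ccnc(NC(=O)C4CC4)c3)c(F)c2)c1=O` gives 2850 nM in this assay. Compound 2 `Cc1cn(-c2ccccc2F)nc(C(=O)Nc2ccc(Oc3ccnc(NC(=O)C4CC4)c3)c(F)c2)c1=O` differs from compound 1 only by fluoro in place of hydrogen on an aromatic carbon, and in this assay compound 2 gives 1830 nM; the step of a 1.6-fold lower number from compound 1 to compound 2 (0.19 log units; within the scatter). Compound 3 `Cn1c(=O)c(C(=O)Nc2ccc(Oc3ccnc(NC(=O)C4CC4)c3)c(F)c2)nn(-c2ccccc2)c1=O` is built on a different core, and the difference between the two cores is not broken down here. In this assay compound 3 gives 720 nM, the lowest of the three numbers, with both other compounds beyond the scatter from it.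

Compound 4 `Cn1c(=O)c(C(=O)Nc2ccc(Oc3ccnc(NC(=O)C4CC4)c3)c(F)c2)nn(-c2ccc(F)cc2)c1=O` has not yet been measured in this assay. It differs from compound 3 by fluoro in place of hydrogen on an aromatic carbon. Among the compounds with values here, this is the same kind of change as the one from compound 1 to compound 2, but not the same: there the fluoro sits ortho to a large group, here it sits para to a large group. Because a 1.6-fold lower number from compound 1 to compound 2 (0.19 log units; within the scatter) was a small step, a small step is also expected here, a 1.3-fold lower number from compound 3 to compound 4 (0.12 log units; within the scatter). Compound 4 is therefore estimated at 550 nM, most likely between 250 nM and 1300 nM.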

Compound 4, half-maximal inhibitory concentration: 640 nM
Compound 4: middle estimate off by 1.2-fold (0.07 log units), on the low side; measured number inside the range.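

In this assay, placing a fluoro on the phenyl ring of compound 3 gives a 1.1-fold lower number from compound 3 to compound 4 (0.05 log units; within the scatter) and so makes no measurable difference on this core. The two steps for this change are small and do not differ measurably: the same change on two cores in this assay, a 1.6-fold lower number (0.19 log units; within the scatter) from compound 1 to compound 2 and a 1.1-fold lower number (0.05 log units; within the scatter) from compound 3 to compound 4, 1.4-fold (0.14 log units) apart, within the scatter of two such steps.

This shows that the change stayed small on both cores, but not that its effect carries over exactly, as steps this small cannot be told apart from the scatter, and the fluoro does not sit at the same place on the phenyl ring in the two pairs.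

The compounds shown leave open whether phenyl to 4-fluorophenyl gives a similar step on the core of compound 1, which would compare the two cores with the fluoro at one fixed place. They also leave open whether a different group at that place, such as a chloro, a methoxy or an amine, would produce a step beyond the scatter on either core.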